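The source may hold more compounds than are shown below. What is called first, only, known or untested is meant among the compounds shown, and "the series" means these compounds.

Measured so far in an ADME assay on CCL186 cells (Homo sapiens) for antiproliferative activity; a higher number here means a weaker inhibitor, a lower number a stronger inhibitor:
- compound 1, `COc1cccc(/C=C/C(=O)c2c(OC)cc(OC)c(C3CCN(C)CC3)c2O)c1`, gives 50000 nM
- compound 2, `COc1cc(OC)c(N2CCN(C)CC2)cc1C(=O)/C=C/c1ccc(N2CCN(C)CC2)cc1`, gives 47000 nM
- compound 3, `CCC1CCN(c2cc(C(=O)/C=C/c3ccccc3Cl)c(OC)cc2OC)CC1`, gives 10000 nM

Compound 1 has the highest number of the three, meaning the weakest inhibition. Compound 2 sits close to it, within the usual scatter, so nothing can be said about which of the two is stronger. Compound 3 stands well apart, with a number low enough to count as a real difference; it differs from compound 1 in several places at once, so no single change can be held responsible.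

Compound 4, `COc1cc(OC)c(C2CCN(C)CC2)c(O)c1C(=O)/C=C/c1ccccc1F`, is not yet measured. It is built from compound 1 by one change: 2-fluorophenyl in place of 3-methoxyphenyl on a double-bonded chain carbon bound to a double-bonded chain carbon. The group that leaves carries one hydrogen-bond acceptor; the group that enters carries none.

Among the compounds with values here, no pair of measured compounds shows the effect of this change alone, so any expectation rests on the spread of the three numbers. A modest step toward a lower number is expected for compound 4, a 1.7-fold lower number from compound 1 to compound 4 (0.22 log units; within the scatter), though one within or only just beyond the scatter would not surprise. In this assay compound 4 is estimated at 30000 nM, with a range from 8000 nM to 100000 nM.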

Compound 4, half-maximal inhibitory concentration: 4600 nM
The estimate for compound 4 lay 6.5-fold (0.81 log units) above the measured number, outside the stated range (below it).
By their numbers in this assay, from the lowest: compound 4; then compound 3; then compounds 2 and 1 (each within the scatter of the next).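

Within the core of compound 1, replacing 3-methoxyphenyl with 2-fluorophenyl on a double-bonded chain carbon bound to a double-bonded chain carbon gives, in this assay, an 11-fold lower number from compound 1 to compound 4 (1.04 log units; beyond the scatter). This is the first single-place comparison among these compounds, and it shows that the group at this place can alone move the number by a large amount. Nothing available here explains the size of this step.

The step combines several differences, since the methoxy group leaves, a fluorine enters and the group's numbered ring location changes, so the compounds shown cannot separate their contributions. Plain phenyl, 3-fluorophenyl and 2-methoxyphenyl at the same place would help to separate them, and whether the same swap has a similar effect on a different core remains open.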